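The compounds below may be only part of what the source reports. "The series", "measured", "known", "first", "only" and "open" are said of these compounds alone.

Measured compounds:
compound 1 `CCCCCn1cc(COc2ccc(/C=C/C(=O)c3cc4c(cc3O)OC(C)(C)CC4)cc2)nn1` — 91300 nM
compound 2 `CCCCCCCCn1cc(COc2ccc(/C=C/C(=O)c3cc4c(cc3O)OC(C)(C)CC4)cc2)nn1` — 50800 nM
compound 3 `CCCCCn1cc(COc2ccc(/C=C/C(=O)c3ccc4c(c3O)CCC(C)(C)O4)cc2)nn1` — 48600 nM

The read-out throughout is a functional assay on A549 cells (Homo sapiens) for antiproliferative activity, read by MTT assay; a higher number here means a weaker inhibitor, a lower number a stronger inhibitor. Compound 1 and compound 2 share one core and differ by propyl in place of hydrogen on a saturated chain carbon, five bonds along the chain from an aromatic nitrogen; the measured step is a 1.8-fold lower number from compound 1 to compound 2 (0.25 log units; within the scatter). Compound 3 carries a different core; how the core of compound 3 differs from the core of compound 1 is not broken down here. Against compound 2, compound 3 gives a number that lies within the scatter; against compound 1 the gap is also within the scatter, so no ordering of the three is read from these values.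

Compound 4 `CCCCCCCCn1cc(COc2ccc(/C=C/C(=O)c3ccc4c(c3O)CCC(C)(C)O4)cc2)nn1` is not yet measured. It stands to compound 3 as compound 2 stands to compound 1: the change is propyl in place of hydrogen on a saturated chain carbon, five bonds along the chain from an aromatic nitrogen, and the two place descriptions agree word for word, so it is the same change, seen here for the second time. Among the compounds with values here, the only guide is the step from compound 1 to compound 2, which was small and within the scatter. The step from compound 3 to compound 4 is therefore expected to be of comparable size, a 1.6-fold lower number from compound 3 to compound 4 (0.21 log units; within the scatter), because the same change gave a 1.8-fold lower number from compound 1 to compound 2 (0.25 log units; within the scatter). On that basis compound 4 is estimated at 30000 nM, with a range from 12000 nM to 75000 nM.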

Compound 4, half-maximal inhibitory concentration: "not active" (no number reported)
For compound 4 the study gives words and no number; there is nothing to compare the estimate with.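

In this assay, within the data shown here, compound 4 is reported in words only, as "not active", so no step from compound 3 to compound 4 can be read. The compounds shown leave open whether the change from hydrogen to propyl acts on the core of compound 3 as it does on the core of compound 1. No further data bear on this result.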